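The source may report more compounds than this note shows. Statements on the series, on what has been measured and on what is new or still open speak of the compounds shown alone.

Measured compounds:
- Compound 1 `Cc1nc2cnccc2n1-c1ccc(I)cc1`: 67 nM
- Compound 2 `Cc1nc2cnccc2n1-c1ccc(C2CC(=O)Nc3cc(Cl)c(Cl)cc3C2)cc1`: 0.5 nM

In a functional assay (Oryctolagus cuniculus) for antagonist activity at platelet-activating factor receptor (Cavia porcellus) (on this read-out lower numbers stand for stronger inhibition and higher numbers for weaker inhibition), compound 2 gives the lowest of the two numbers; the nearest is compound 1, whose value is higher by a margin beyond the scatter. Compound 3 `Cc1nc2cnccc2n1-c1ccc(C2CC(=O)N(C)c3cc(Cl)c(Cl)cc3C2)cc1` is not yet measured in this assay. It differs from compound 2 by methyl in place of hydrogen on an amide-type nitrogen in a ring. Going by the values given here, no step between measured compounds bears on this change, so its size is uncertain; a modest loss is expected, with a 3.0-fold higher number from compound 2 to compound 3 (0.48 log units; beyond the scatter) likely within or just beyond the scatter. Compound 3 is estimated at 1.5 nM, range 0.3 nM to 8 nM.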

Compound 3, half-maximal inhibitory concentration: 0.5 nM
Beside the measured number, compound 3's estimate is 3.0-fold (0.48 log units) above it; measured number inside the range.
By their numbers in this assay, from the lowest: compounds 2 and 3 (each within the scatter of the next); then compound 1.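

In this assay, methyl in place of hydrogen on the amide-type nitrogen in the seven-membered ring gives no change at the digits printed from compound 2 to compound 3 (within the scatter) and so leaves the read-out unmoved. For this pair, the amide hydrogen is therefore not needed to keep the number at the level of compound 2. Nothing available bears on why the change is tolerated.

Going by these compounds, whether this nitrogen also accepts a longer chain such as ethyl or benzyl, or a chain ending in an amine or a carboxylic acid, remains open. Whether the tolerance extends beyond methyl cannot be judged from this single step.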